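A few compounds are considered here, and "the series" means these few. Any claim that something is new, unique, unknown or untested is made for them only; others in the source may bear on it.

Of the compounds shown here, three that share one core have so far been tested in a functional assay on WRL68 cells (Homo sapiens) for cytotoxicity, read by MTT assay, with a stated time of 4 h; a lower number here means a stronger inhibitor, a higher number a weaker inhibitor. Compound 1 `COC(=O)C1=CO[C@@H](O[C@@H]2O[C@H](CO)[C@@H](OC(C)=O)[C@H](OC(C)=O)[C@H]2OC(C)=O)[C@@H]2[C@@H](C)[C@@H](OC(C)=O)C[C@H]12` is reported as "not active" (no number reported) with no number attached. For the measured compounds named here, compound 2 `CCC(=O)OC[C@H]1O[C@@H](O[C@@H]2OC=C(C(=O)OC)[C@H]3C[C@H](OC(C)=O)[C@H](C)[C@@H]23)[C@H](OC(C)=O)[C@@H](OC(C)=O)[C@@H]1OC(C)=O` gives 2.65 ug/mL in this assay and compound 3 `CCCCCCCCCCCC(=O)OC[C@H]1O[C@@H](O[C@@H]2OC=C(C(=O)OC)[C@H]3C[C@H](OC(C)=O)[C@H](C)[C@@H]23)[C@H](OC(C)=O)[C@@H](OC(C)=O)[C@@H]1OC(C)=O` gives 0.85 ug/mL there, which makes compound 3 the lower of the only two numbers available.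

Compound 4 `C=CC(=O)OC[C@H]1O[C@@H](O[C@@H]2OC=C(C(=O)OC)[C@H]3C[C@H](OC(C)=O)[C@H](C)[C@@H]23)[C@H](OC(C)=O)[C@@H](OC(C)=O)[C@@H]1OC(C)=O` is still unmeasured. It has vinyl in place of undecyl on a carbonyl carbon and is otherwise the same as compound 3.

Going by the values given here, one measured step bears on this change. Putting nonyl in place of hydrogen on a saturated chain carbon, two bonds along the chain from a carbonyl carbon, gave a 3.1-fold lower number from compound 2 to compound 3 (0.49 log units; beyond the scatter) and so a modest shift beyond the scatter. The change to compound 4 removes a long chain rather than adding one, so a step of similar size in the opposite direction, towards a higher number in this assay, is expected. Vinyl itself has no measurement behind it, so this rests on a single step and the range stays wide. The expected step is a 2.9-fold higher number from compound 3 to compound 4 (0.47 log units; beyond the scatter) in this estimate. For compound 4 the estimated value is 2.5 ug/mL with an expected range of 0.9 ug/mL to 7 ug/mL in this assay.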

Compound 4, half-maximal inhibitory concentration: "not active" (no number reported)
No number was reported for compound 4; no gap can be computed for the estimate.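

Compound 4 is reported as not active with no number attached, so the change from compound 3 to compound 4 cannot be read as a step of any size. The compounds shown leave open how far vinyl in place of undecyl shifts the result in this assay on a numerical scale. Nothing measured here offers an explanation for this outcome.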